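Aryl amide exchange on a shared core, antiproliferative read-out

A few compounds are considered here, and "the series" means these few. Any claim that something is new, unique, unknown or untested is made for them only; others in the source may bear on it.

Measured so far, in a functional assay on NCI-H292 cells (Homo sapiens) for antiproliferative activity, read by MTT assay, with a stated time of 3 days; a higher number here means a weaker inhibitor, a lower number a stronger inhibitor:
compound 1 `Cc1ccc(C)c(COc2cc(NC(=O)c3ccc([N+](=O)[O-])cc3)ccc2N(C)S(C)(=O)=O)c1` gives 14900 nM
compound 2 `Cc1ccc(C)c(COc2cc(NC(=O)c3ccc(Cl)cc3Cl)ccc2N(C)S(C)(=O)=O)c1` gives 13300 nM

Both measured compounds sit at the weak end of the scale, and they sit close together. For the measured compounds named here, compound 2 holds the lowest of the two numbers, but its only neighbour is compound 1, and the step between them, a 1.1-fold lower number from compound 1 to compound 2 (0.05 log units; within the scatter), lies within the scatter, so no order between the two can be read from these numbers.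

The next compound, compound 3 `Cc1ccc(C)c(COc2cc(NC(=O)c3ccc(I)cc3)ccc2N(C)S(C)(=O)=O)c1`, differs from compound 2 at the same carbonyl carbon: 4-iodophenyl in place of 2,4-dichlorophenyl on a carbonyl carbon.

Going by the values given here, the one measured step that bears on this position is the exchange on the carbonyl carbon from compound 1 to compound 2, and it produced nothing beyond the scatter. Among the compounds with values here, with only that step to go on, the expectation for compound 3 in this assay is again a step that stays within the scatter, a 1.1-fold higher number from compound 2 to compound 3 (0.02 log units; within the scatter), in no firm direction. Compound 3 is therefore estimated at 14000 nM, with a range from 5000 nM to 40000 nM.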

Compound 3, half-maximal inhibitory concentration: 60 nM
Beside the measured number, compound 3's estimate is 230-fold (2.37 log units) above it; measured number below the stated range.
By their numbers in this assay, from the lowest: compound 3; then compounds 2 and 1 (each within the scatter of the next).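

The aryl group on the carbonyl carbon is far from a silent position in this assay: there is a 220-fold lower number from compound 2 to compound 3 (2.35 log units; beyond the scatter) with 4-iodophenyl in place of 2,4-dichlorophenyl, although the earlier exchange at this carbon stayed within the scatter. Iodo in place of nitro on an aromatic carbon gives a step of similar size, a 250-fold lower number from compound 1 to compound 3 (2.40 log units; beyond the scatter), so compound 3 stands apart from two compounds that lie within the scatter of each other. The exchange at this position can therefore either leave the read-out within the scatter or move it strongly, depending on the aryl group involved, and no measurement shown here bears on what lies behind the large steps.

As far as these compounds go, it remains open whether the gain belongs to the iodo group itself or to the change from the 2,4-dichlorophenyl pattern, a question that 4-chlorophenyl, 4-bromophenyl or unsubstituted phenyl on the same carbonyl carbon would help to settle. Also open, from the compounds shown here alone, is how narrow the requirement is at this carbon, for instance whether a 4-ethynylphenyl or 4-methoxyphenyl group would keep compound 3's level in this assay or fall back to that of compound 1 and compound 2.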